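Methyl on the benzoxazole of compound 3: expected effect

A few compounds are considered here, and "the series" means these few. Any claim that something is new, unique, unknown or untested is made for them only; others in the source may bear on it.

Values in a functional assay on CHO cells for agonist activity at prostaglandin E2 receptor EP2 subtype (Rattus norvegicus), read by cAMP accumulation and immunoassay, with a stated time of 10 min (on this read-out higher numbers stand for an effect only at larger amounts of compound and lower numbers for an effect already at smaller amounts), for the measured compounds:
compound 1 `O=C(O)c1csc(SCCN2C(=O)CC[C@@H]2/C=C/[C@@H](O)Cc2cccc(-c3ccccc3)c2)n1`: 1800 nM
compound 2 `O=C(O)c1csc(SCCN2C(=O)CC[C@@H]2/C=C/[C@@H](O)Cc2cccc(-c3ccc(Cl)cc3)c2)n1`: 260 nM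
compound 3 `O=C(O)c1csc(SCCN2C(=O)CC[C@@H]2/C=C/[C@@H](O)Cc2cccc(-c3nc4ccccc4o3)c2)n1`: 1600 nM

Compound 3 sits second highest of the three numbers. Its nearest neighbour is compound 1, with a 1.1-fold lower number from compound 1 to compound 3 (0.05 log units; within the scatter) lying within the scatter, so the two cannot be ordered. Compound 2 is the furthest, and a 6.2-fold higher number from compound 2 to compound 3 (0.79 log units; beyond the scatter) is beyond the scatter.

Compound 4 `Cc1ccc2oc(-c3cccc(C[C@H](O)/C=C/[C@H]4CCC(=O)N4CCSc4nc(C(=O)O)cs4)c3)nc2c1` differs from compound 3 by methyl in place of hydrogen on an aromatic carbon.

Within the data shown here, no measured step adds a substituent to the benzoxazole, so nothing bears on this change directly. Among the measured compounds shown here, the only substituent step in the set is a 6.9-fold lower number from compound 1 to compound 2 (0.84 log units; beyond the scatter), a modest lowering from a chloro on the pendant phenyl; a methyl on a fused ring is a different change, and a 1.1-fold lower number from compound 1 to compound 3 (0.05 log units; within the scatter) shows that swapping phenyl for benzoxazolyl itself left the number unchanged. The expectation for compound 4 is therefore a small lowering at most, a 1.6-fold lower number from compound 3 to compound 4 (0.20 log units; within the scatter), with the outcome possibly staying within the scatter. Compound 4 is estimated at 1000 nM, with a range from 350 nM to 3000 nM.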

Compound 4, half-maximal effective concentration: > 10000 nM
Compound 4: only a limit was reported; the forecaster's own chance of this, stated with the estimate: 5%; middle value at least 10-fold (1.00 log units) away from the limit.
By their numbers in this assay, from the lowest: compound 2; then compounds 3 and 1 (each within the scatter of the next). At a limit, above all of these: compound 4.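

In this assay compound 4 is recorded only as a limit: the limit of > 10000 nM in this assay, at which 1 of the 4 values shown sits. The benzoxazole therefore does not tolerate every change: going from 1,3-benzoxazol-2-yl to 5-methyl-1,3-benzoxazol-2-yl, a change of one carbon, gives an at least 6.2-fold higher number from compound 3 to compound 4 (0.79 log units; beyond the scatter), whereas replacing phenyl with the unsubstituted benzoxazole had given only a 1.1-fold lower number from compound 1 to compound 3 (0.05 log units; within the scatter). A small added group on this aromatic arm can also move the number in either direction: chloro on the pendant phenyl gave a 6.9-fold lower number from compound 1 to compound 2 (0.84 log units; beyond the scatter), methyl on the benzoxazole goes the opposite way, and the remaining steps, an at least 5.5-fold higher number from compound 1 to compound 4 (0.74 log units; beyond the scatter) and an at least 38-fold higher number from compound 2 to compound 4 (1.58 log units; beyond the scatter), set this limit above all the other numbers shown.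

As far as these compounds go, whether the rise belongs to methyl itself or to any group on this carbon remains open, and a fluoro or methoxy there, or a methyl on another carbon of the six-membered ring, would separate these readings. The true size of the step also remains unknown, as does any reason for it, since the compounds shown provide only a limit and a single substitution on the benzoxazole.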